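Swapping the Isopropyl Amine Substituent in Compound 1

The compounds below may be only part of what the source reports. "The series", "measured", "known", "first", "only" and "open" are said of these compounds alone.

Measured compounds in an assay for inhibition of Maternal embryonic leucine zipper kinase (Homo sapiens), read by ADP-Glo, with a stated time of 0.5 h; a higher number here means a weaker inhibitor, a lower number a stronger inhibitor:
- compound 1 `CC(C)Nc1sc(C(=O)c2ccc(Br)s2)c(N)c1C#N` gives 122 nM
- compound 2 `CC(C)Nc1sc(C(=O)c2ccc(-c3ccc(O)cc3)s2)c(N)c1C#N` gives 241 nM
- compound 3 `CC(C)Nc1sc(C(=O)c2ccc(-c3cccc(O)c3)s2)c(N)c1C#N` gives 350 nM

Compound 1 has the lowest number of the three. The step of a 2.0-fold higher number from compound 1 to compound 2 (0.30 log units; within the scatter) lies within the scatter, whereas the step of a 2.9-fold higher number from compound 1 to compound 3 (0.46 log units; beyond the scatter) is modest and beyond it. Compound 4 `N#Cc1c(NCC(N)=O)sc(C(=O)c2ccc(Br)s2)c1N` differs from compound 1 by carbamoylmethyl in place of isopropyl on a nitrogen on an aromatic ring, an isopropylamino becoming a (carbamoylmethyl)amino. Among the measured compounds shown here, none of the measured steps touches that nitrogen; all of them change the group on the aromatic carbon that carries bromo in compound 1, so no measured step bears on this change. With nothing to go on, a step of no more than modest size in either direction is expected, and compound 4 is estimated at 200 nM (range 60 nM to 700 nM), which corresponds to an expected step of a 1.6-fold higher number from compound 1 to compound 4 (0.21 log units; within the scatter).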

Compound 4, half-maximal inhibitory concentration: 540 nM
Beside the measured number, compound 4's estimate is 2.7-fold (0.43 log units) below it; measured number inside the range.
By their numbers in this assay, from the lowest: compounds 1, 2, 3 and 4 (each within the scatter of the next, the first and the last beyond it).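

Carbamoylmethyl in place of isopropyl on this nitrogen gives a weaker inhibitor in this assay, with a 4.4-fold higher number from compound 1 to compound 4 (0.65 log units; beyond the scatter). Among the compounds shown here, this is the first sign that the group on this nitrogen matters, as the earlier steps all changed the group that carries bromo in compound 1. Nothing available explains the loss.

From the compounds shown here alone, it remains open whether the carbamoyl part or the replacement of isopropyl itself drives this step, which a simple ethyl or a 2-hydroxyethyl group on the same nitrogen could help separate. A cyclopentyl group or a longer alkyl chain there also remains untested in the compounds shown.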